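The compounds below may be only part of what the source reports. "The series", "measured", "known", "first", "only" and "open" are said of these compounds alone.

Compound 1 `O=C(NCC1CCOCC1)c1cnc(Nc2cc(Cl)cc(Cl)c2)cc1C1CC1` gives "not determined" (no result reported) in an in vitro ADME assay on microsomes from liver (Homo sapiens) for metabolic stability; on this read-out higher numbers stand for fast clearance and lower numbers for slow clearance.
Compound 2 `N#Cc1cccc(Nc2cc(C3CC3)c(C(=O)NCC3CCOCC3)cn2)c1` gives "not determined" (no result reported) in this assay.
Compound 3 `CC(C)(C)c1cc(Nc2ccc(Cl)cc2Cl)ncc1C(=O)NCC1CCOCC1` gives < 0.5 mL.min-1.g-1 in this assay, which is a limit of the assay and not a number.

Compound 2 has no single number in this assay; alongside it one further value is a limit and one further entry carries no number at all. Compound 4 `O=C(NCC1CCOCC1)c1cnc(Nc2cccc(OC(F)(F)F)c2)cc1C1CC1` is the next compound and differs from compound 2 by trifluoromethoxy in place of cyano on an aromatic carbon. Within the data shown here, no measured step of this kind exists, so the expected size and direction of any step in this assay cannot be read from a measured pair, and only a broad range can be given. Compound 4 is expected to give about 1 mL.min-1.g-1, within 0.3 mL.min-1.g-1 to 3 mL.min-1.g-1, in this assay.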

Compound 4, intrinsic clearance in microsomes: 1 mL.min-1.g-1
For compound 4 middle estimate and measured number coincide at the digits printed, and the stated range covers the measured number.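

Among these compounds, compound 2 has no single number in this assay, so no step from it to compound 4 can be read. Left open is how trifluoromethoxy in place of cyano shifts clearance in this series.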